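Demethylation of the aryl methyl ether in compound 2

A few compounds are considered here, and "the series" means these few. Any claim that something is new, unique, unknown or untested is made for them only; others in the source may bear on it.

Two compounds of the series have numbers in a functional assay on UACC-62 cells (Homo sapiens) for inhibition, read by sulforhodamine B assay, with a stated time of 48 h; a lower number here means a stronger inhibitor of growth, a higher number a weaker inhibitor of growth. Compound 1 `COc1cc(C)cc(-c2c(-c3ccnc(-c4ccc(N(C)C)cc4)c3)cnn2CC#N)c1` gives 61.9 nM in this assay. Compound 2 `COc1cc(C)cc(-c2nn(CC#N)cc2-c2ccnc(-c3ccc(N(C)C)cc3)c2)c1` gives 337 nM in this assay, the higher of the two numbers, and the gap to compound 1 lies beyond the usual scatter. Compound 3 `Cc1cc(O)cc(-c2nn(CC#N)cc2-c2ccnc(-c3ccc(N(C)C)cc3)c2)c1` has not been measured; it differs from compound 2 by hydrogen in place of methyl on an oxygen on an aromatic ring. Among the compounds with values here, no measured pair shows what this change does here, so the expectation for compound 3 rests on the value of compound 2 alone. Compound 3 is estimated to stay near compound 2, the step of a 1.1-fold lower number from compound 2 to compound 3 (0.05 log units; within the scatter) being expected to fall within the scatter, with either direction possible. For compound 3 the estimate in this assay is 300 nM, with a range from 100 nM to 900 nM.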

Compound 3, concentration for 50% growth inhibition: 3050 nM
For compound 3 the middle estimate is 10-fold (1.01 log units) below the measured one, outside the stated range (above it).
By their numbers in this assay, from the lowest: compound 1; then compound 2; then compound 3.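

Methoxy to hydroxy on the 3-methoxy-5-methylphenyl group now has a first measured reading in the series: in this assay it gives a 9.1-fold higher number from compound 2 to compound 3 (0.96 log units; beyond the scatter) and lies beyond the scatter. This oxygen on an aromatic ring is therefore not a neutral place for change, as the loss of one methyl, a single carbon, moves growth inhibition clearly toward the weaker side in this series. No available measurement bears on the reason for this step.

Still open, from the compounds shown here alone, is how other groups on this oxygen would read, such as an ethyl or a longer chain, or how an amine or a fluorine would read in place of the methoxy group. Also open, going by these compounds, is whether the same change on the core of compound 1 would give a step of similar size.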